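The source may hold more compounds than are shown below. What is called first, only, known or untested is meant among the compounds shown, and "the series" means these compounds.

Compound 1 `CCS(=O)(=O)N1CCC(c2cncc(N3C(=O)c4ccc(Cl)cc4C3(C)C)c2)CC1`: 3 nM
Compound 2 `O=C1c2cc(F)c(Cl)cc2CCN1c1cccnc1`: 104 nM
Compound 3 `Cn1cc(C(=O)N2CC3(C2)CN(c2cncc(N4C(=O)c5ccc(Cl)cc5C4(C)C)c2)C3)cn1`: 2 nM

All three were tested in an assay on cells for inhibition of cytochrome P450 11B2, mitochondrial (Homo sapiens), read by HTRF; on this read-out lower numbers stand for stronger inhibition and higher numbers for weaker inhibition. Compound 3 gives the lowest of the three numbers, but its gap to compound 1 lies within the usual scatter of repeated measurements, so those two cannot be ranked against each other. Compound 2 lies far above both, well beyond the scatter.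

Compound 4 `CCS(=O)(=O)N1CC2(CN(c3cncc(N4C(=O)c5ccc(Cl)cc5C4(C)C)c3)C2)C1` has not yet been measured. It differs from compound 3 in one place: ethylsulfonyl in place of (1-methyl-1H-pyrazol-4-yl)carbonyl on an amine nitrogen in a ring. The spiro core itself stays as it is. Compound 1 also carries an ethylsulfonyl group on an amine nitrogen in a ring, and in this assay compound 1 gives 3 nM, close to the number for compound 3. Among the measured compounds shown here, no measured pair shows this exact exchange on this core, so the expectation rests on that comparison alone, and it points to the exchange leaving the result roughly where it is.

In this assay the expected step is a 1.5-fold higher number from compound 3 to compound 4 (0.18 log units; within the scatter), which means no change beyond the scatter in either direction. Compound 4 is therefore estimated to give 3 nM in this assay, with a range from 1 nM to 9 nM.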

Compound 4, half-maximal inhibitory concentration: 16 nM
Compound 4: the middle estimate sits 5.3-fold (0.73 log units) below what was measured, and the stated range ends below it.
By their numbers in this assay, from the lowest: compounds 3 and 1 (each within the scatter of the next); then compound 4; then compound 2.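

In this assay, the group on this amine nitrogen of the four-membered ring clearly matters: putting ethylsulfonyl in place of (1-methyl-1H-pyrazol-4-yl)carbonyl brings an 8.0-fold higher number from compound 3 to compound 4 (0.90 log units; beyond the scatter). The same ethylsulfonyl group on the core of compound 1 goes with 3 nM, while on the core of compound 3 it gives compound 4 with 16 nM, so a group's result on one core did not carry over to the other here. No accompanying measurement bears on this step, so the data offer no explanation for it.

This single exchange changes the carbonyl and the five-membered aromatic ring together, so it cannot say which part of the departing group counts: an acetyl group would keep the carbonyl without that ring, and a phenylsulfonyl group would pair the sulfonyl with an aromatic ring. The (1-methyl-1H-pyrazol-4-yl)carbonyl group on the core of compound 1 would show whether the gap between the two groups also appears on that core or belongs to the core of compound 3 alone.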